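The source may hold more compounds than are shown below. What is called first, only, known or untested is meant among the compounds shown, and "the series" means these compounds.

Among the compounds with values here, in a functional assay on MGC-803 cells (Homo sapiens) for inhibition, read by MTT assay, with a stated time of 72 h (on this read-out lower numbers stand for stronger inhibition and higher numbers for weaker inhibition), three compounds with a shared core have numbers so far. Compound 1 `Cc1cc(Nc2cc(-c3ccccc3)[nH]n2)n2nc(SCc3cccc(Br)c3)nc2n1` gives 4820 nM, compound 2 `Cc1cc(Nc2cc(-c3ccccc3)[nH]n2)n2nc(SCc3ccc(Cl)cc3)nc2n1` gives 3950 nM, and compound 3 `C=CCSc1nc2nc(C)cc(Nc3cc(-c4ccccc4)[nH]n3)n2n1` gives 17200 nM. Compound 3 therefore has the highest number and is the weakest of the three. Exchanging one aromatic group for the other barely registers: a 1.2-fold lower number from compound 1 to compound 2 (0.09 log units; within the scatter). Putting vinyl in place of either aromatic group matters more, though still modestly: a 3.6-fold higher number from compound 1 to compound 3 (0.55 log units; beyond the scatter) and a 4.4-fold higher number from compound 2 to compound 3 (0.64 log units; beyond the scatter). Compound 4 `CCCSc1nc2nc(C)cc(Nc3cc(-c4ccccc4)[nH]n3)n2n1` differs from compound 3 by one small change: ethyl in place of vinyl on a saturated chain carbon bound to a sulfur. In short, allyl becomes propyl. Neither group has a ring, whereas both of those larger steps removed one. Within the data shown here, no measured step compares vinyl with ethyl directly, so the range stays wide. In this assay no step beyond the scatter is expected, and the expected step is a 1.1-fold lower number from compound 3 to compound 4 (0.06 log units; within the scatter). For compound 4 the estimated value is 15000 nM, with an expected range from 7000 nM to 32000 nM.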

Compound 4, half-maximal inhibitory concentration: 12600 nM
The estimate for compound 4 lay 1.2-fold (0.08 log units) above the measured number, within the range that was stated.
By their numbers in this assay, from the lowest: compounds 2 and 1 (each within the scatter of the next); then compounds 4 and 3 (each within the scatter of the next).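

In this assay, saturating the double bond of the chain makes no difference that can be told from scatter (a 1.4-fold lower number from compound 3 to compound 4 (0.14 log units; within the scatter)), so allyl and propyl read alike here. Compound 4 therefore shows that the gap to the compounds carrying an aromatic ring does not depend on that double bond: the saturated chain also falls short of both (a 3.2-fold higher number from compound 2 to compound 4 (0.50 log units; beyond the scatter); a 2.6-fold higher number from compound 1 to compound 4 (0.42 log units; beyond the scatter)). No measurement shown here explains these differences.

From the compounds shown here alone, it remains open how the number would respond to a chain longer than propyl, or to an amine or a carboxylic acid at the end of the chain. It is also unclear whether the aromatic ring itself matters or simply a larger group, a question that a cyclohexyl ring on the saturated chain carbon bound to the sulfur could help to answer.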